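Cytotoxicity of quinolone sulfonamides: changing the nitrogen substituent

The source may report more compounds than this note shows. Statements on the series, on what has been measured and on what is new or still open speak of the compounds shown alone.

In an ADME assay on 2209-23 cells (Homo sapiens) for cytotoxicity, read by WST assay (on this read-out higher numbers stand for lower toxicity in this test and lower numbers for higher toxicity in this test), compound 1 `CS(=O)(=O)Nc1ccc2c(c1)S(=O)(=O)C=C(c1c(O)c3cc(F)ccc3n(Cc3ccc(F)c(F)c3)c1=O)N2` gives > 50000 nM, a limit of the assay rather than a number. Compound 2 `COc1cc(Cn2c(=O)c(C3=CS(=O)(=O)c4cc(NS(C)(=O)=O)ccc4N3)c(O)c3cc(F)ccc32)ccc1F` gives > 50000 nM in this assay, again a limit. Compound 3 `CS(=O)(=O)Nc1ccc2c(c1)S(=O)(=O)C=C(c1c(O)c3cc(F)ccc3n(CC3CCCCC3)c1=O)N2` gives > 50000 nM in this assay, also a limit.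

Compound 3 therefore stands only at a limit, and the same is true of both other compounds, as shown by the limit of > 50000 nM in this assay, at which 3 of the 3 values shown sit. The steps among them are accordingly not readable: a step that the two limits leave unreadable from compound 1 to compound 2, a step that the two limits leave unreadable from compound 1 to compound 3 and a step that the two limits leave unreadable from compound 2 to compound 3 all stay hidden behind the limit.

Compound 4 `CCCC(C)n1c(=O)c(C2=CS(=O)(=O)c3cc(NS(C)(=O)=O)ccc3N2)c(O)c2cc(F)ccc21`, still to be measured in this assay, differs from compound 3 in one place: 1-methylbutyl in place of cyclohexylmethyl on an aromatic nitrogen. The steps from compound 1 and from compound 2 to compound 3 bear on this change, since they also swap the group on the aromatic nitrogen, yet their size cannot be read. Within the data shown here, no measured step gives a direction, so no shift beyond the scatter is expected, and the step from compound 3 to compound 4 is estimated as a step that the limit leaves unreadable from compound 3 to compound 4. Compound 4 is expected to give about 60000 nM in this assay, within a range from 20000 nM to 200000 nM, most probably reported again as a limit.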

Compound 4, half-maximal cytotoxic concentration: > 50000 nM
Compound 4 ended at the assay's limit; the forecaster's own chance of this, stated with the estimate: 80%; the middle value does not contradict the limit.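

Among these compounds, no step from compound 1, compound 2 or compound 3 to compound 4 can be read in this assay, because all four compounds sit at the same limit: the limit of > 50000 nM in this assay, at which 4 of the 4 values shown sit. The compounds shown leave open whether changing the group on the aromatic nitrogen alters cytotoxicity at all, and by how much, as none of them gives an actual number.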